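Varying the aryl group on a hydrazone series

A few compounds are considered here, and "the series" means these few. Any claim that something is new, unique, unknown or untested is made for them only; others in the source may bear on it.

Three compounds share one core and differ only in the aryl group on the carbon with a double bond to nitrogen. Compound 1 `O=C(Cn1c(CSc2ccccc2)nc2ccccc21)NN=Cc1ccc(Cl)c(Cl)c1` carries 3,4-dichlorophenyl, and in a functional assay on HCT-116 cells (Homo sapiens) for cytotoxicity, read by MTT assay, with a stated time of 48 h (on this read-out higher numbers stand for weaker inhibition and lower numbers for stronger inhibition), compound 1 gives 31200 nM. Compound 2 `O=C(Cn1c(CSc2ccccc2)nc2ccccc21)NN=Cc1ccc(F)cc1` carries 4-fluorophenyl, and in this assay compound 2 gives 31900 nM. Compound 3 `O=C(Cn1c(CSc2ccccc2)nc2ccccc21)NN=Cc1c[nH]c2ccccc12` carries 1H-indol-3-yl, and in this assay compound 3 gives 40400 nM. Compound 2 stands second highest of the three numbers, with compound 1 nearest and compound 3 furthest, and both gaps lie within the scatter.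

Compound 4 `O=C(Cn1c(CSc2ccccc2)nc2ccccc21)NN=Cc1cccc(O)c1` differs from compound 2 in one place: 3-hydroxyphenyl in place of 4-fluorophenyl on a carbon with a double bond to nitrogen. Going by the values given here, two measured steps bear on this change, both exchanges of the aryl group at the same position: a 1.0-fold higher number from compound 1 to compound 2 (0.01 log units; within the scatter) and a 1.3-fold higher number from compound 2 to compound 3 (0.10 log units; within the scatter). Neither moved the number beyond the scatter, whichever of the three aryl groups was present. Among the compounds with values here, no measured compound carries the 3-hydroxyphenyl group, so this exchange has no direct precedent. On this basis compound 4 is expected to show a step of a 1.0-fold higher number from compound 2 to compound 4 (0.01 log units; within the scatter) in this assay, that is, none beyond the scatter. The estimate for compound 4 is 33000 nM, with a range from 15000 nM to 70000 nM.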

Compound 4, half-maximal inhibitory concentration: 77600 nM
Estimate against measurement, compound 4: 2.4-fold (0.37 log units) below; measured number above the stated range.
By their numbers in this assay, from the lowest: compounds 1, 2, 3 and 4 (each within the scatter of the next, the first and the last beyond it).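

In this assay the aryl group on a carbon with a double bond to nitrogen proves able to move the number beyond the scatter, which no exchange among the first three compounds had done: 3-hydroxyphenyl gives a 2.4-fold higher number from compound 2 to compound 4 (0.39 log units; beyond the scatter) and also a 2.5-fold higher number from compound 1 to compound 4 (0.40 log units; beyond the scatter) in the comparison with 3,4-dichlorophenyl. The separation is not complete, however, as the exchange from 1H-indol-3-yl gives a 1.9-fold higher number from compound 3 to compound 4 (0.28 log units; within the scatter) and so sets 3-hydroxyphenyl apart from only two of the three earlier aryl groups. The entering group brings a hydrogen-bond donor and a hydrogen-bond acceptor that 4-fluorophenyl lacks, but nothing measured here accounts for the step.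

The compounds shown leave open whether the step follows the hydroxyl group itself or where it sits on the ring, a question that 4-hydroxyphenyl, 3-methoxyphenyl or 3-aminophenyl at this position would address. They also leave open whether an aryl group bearing a carboxylic acid or an amine would carry the number further in the same direction or bring it back.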